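Opening the ring of compound 1

A few compounds are considered here, and "the series" means these few. Any claim that something is new, unique, unknown or untested is made for them only; others in the source may bear on it.

In an in vivo ADME assay on the whole organism (strain Sprague-Dawley) for pharmacokinetics, with Rattus norvegicus as the target (on this read-out higher numbers stand for wider distribution into tissues and lower numbers for narrower distribution), compound 1 `Cc1cc([C@@H]2C[C@H]2C(=O)O)ccc1-c1noc(-c2ccc(OC(C)C)c(C(F)(F)F)c2)n1` gives 1.1 L/kg as its result, which lies within the scatter of compound 2 `Cc1cc([C@H]2C[C@H]2C(=O)O)ccc1-c1noc(-c2ccc(OC(C)C)c(C#N)c2)n1` at 0.7 L/kg as its result. Compound 3 `Cc1cc([C@@H]2C[C@H]2C(=O)O)ccc1-c1noc(-c2ccc(OC(C)C)c(C#N)c2)n1` returns "not determined" (no result reported); 1 L/kg; 0.4 L/kg (3 entries) across its entries, so small gaps here carry little weight. Compound 4 `Cc1cc(CC(C)C(=O)O)ccc1-c1noc(-c2ccc(OC(C)C)c(C(F)(F)F)c2)n1` carries 2-carboxypropyl in place of 2-carboxycyclopropyl on an aromatic carbon and otherwise keeps the core of compound 1 unchanged. Going by the values given here, no measured step speaks to this change, so the expectation starts from compound 1 at 1.1 L/kg and assumes no shift beyond the scatter. The estimated move a 1.1-fold lower number from compound 1 to compound 4 (0.04 log units; within the scatter) stays within that scatter in this assay as a result. Compound 4 is expected at 1 L/kg with an estimated span of 0.5 L/kg to 2 L/kg as the likely range.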

Compound 4, volume of distribution at steady state: 1.5 L/kg
Estimate against measurement, compound 4: 1.5-fold (0.18 log units) below, and the stated range covers the measured number.
By their numbers in this assay, from the lowest: compounds 2, 1 and 4 (each within the scatter of the next, the first and the last beyond it).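

In this assay, going by these compounds alone, opening the ring at this position gives a 1.4-fold higher number from compound 1 to compound 4 (0.13 log units; within the scatter), the first measured step here. Exchanging 2-carboxycyclopropyl, with its 2 defined stereocentres, for 2-carboxypropyl therefore leaves the volume of distribution within the scatter, so the three-membered ring shows no measurable bearing on this read-out. Even so, small gaps in this read-out carry little weight: the several entries of compound 3 in this assay, "not determined" (no result reported); 1 L/kg; 0.4 L/kg (3 entries)

The compounds shown leave open whether a longer chain carrying the carboxylic acid, or an amine in its place, would move the number beyond the scatter. They also leave open how 2-carboxypropyl behaves alongside the nitrile of compound 2.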